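Trifluoromethyl for Fluoro on the Sulfonamide Analogue

The source may hold more compounds than are shown below. What is called first, only, known or untested is meant among the compounds shown, and "the series" means these compounds.

Compound 1 `CC(C)(C)c1ccc(C(CC(=O)O)NC(=O)c2ccc(F)cc2)cc1`: in a functional assay on MDA-MB-436 cells (Homo sapiens) for antiproliferative activity, read by MTT assay, with a stated time of 24 h (a lower number here means a stronger inhibitor, a higher number a weaker inhibitor), compound 1 reaches only the limit of > 100000 nM, and this is a limit, not a number. 
Compound 2 `CC(C)(C)c1ccc(C(CC(=O)O)NC(=O)c2ccc(C(F)(F)F)cc2)cc1`: compound 2 gives 82300 nM. 
Compound 3 `CC(C)(C)c1ccc(C(CC(=O)O)NS(=O)(=O)c2ccc(F)cc2)cc1`: compound 3 gives 68900 nM.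

The change trifluoromethyl in place of fluoro on an aromatic carbon gave an at least 1.2-fold lower number from compound 1 to compound 2 (0.08 log units; that floor lies within the scatter). The difference between the core of compound 1 and that of compound 3 is not broken down here. Compound 4 `CC(C)(C)c1ccc(C(CC(=O)O)NS(=O)(=O)c2ccc(C(F)(F)F)cc2)cc1` repeats the same change on compound 3, (trifluoromethyl in place of fluoro on an aromatic carbon), at a place described in the same words. Since the measured step rests only on a floor set by the limit of > 100000 nM in this assay, at which 1 of the 3 values shown sits, the expected step of a 1.1-fold lower number from compound 3 to compound 4 (0.06 log units; within the scatter) is small, and for compound 4 a value of 60000 nM is estimated, between 25000 nM and 150000 nM.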

Compound 4, half-maximal inhibitory concentration: 60100 nM
The estimate for compound 4 lay 1.0-fold (0.00 log units) below the measured number; low and high end bracket the measured number.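

In this assay, putting trifluoromethyl in place of fluoro on the sulfonamide core of compound 3 gives a 1.1-fold lower number from compound 3 to compound 4 (0.06 log units; within the scatter). Neither step for this change goes beyond the scatter as printed, yet that does not show that the change acts alike on both cores: the same change on two cores in this assay, an at least 1.2-fold lower number (0.08 log units; that floor lies within the scatter) from compound 1 to compound 2 and a 1.1-fold lower number (0.06 log units; within the scatter) from compound 3 to compound 4; the limit leaves it open whether they differ

The value of compound 1 is a limit and not a number: the limit of > 100000 nM in this assay, at which 1 of the 4 values shown sits.

The compounds shown carry only fluoro or trifluoromethyl at this place, so it remains open whether a nitrile, a methoxy group or an amine there would shift the number beyond the scatter. From the compounds shown here alone, it also remains open what a methyl ester in place of the carboxylic acid would do.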